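The compounds below may be only part of what the source reports. "The series", "measured", "known", "first", "only" and "open" are said of these compounds alone.

Of the compounds shown here, three that share one core have been tested in a functional assay on LNCaP cells (Homo sapiens) for cytotoxicity, read by MTT assay, with a stated time of 48 h; on this read-out lower numbers stand for stronger inhibition and higher numbers for weaker inhibition. Compound 1 `c1ccc(-c2nc(-c3c[nH]c4ccccc34)co2)cc1` gives 461000 nM, compound 2 `Cc1nc(-c2c[nH]c3ccccc23)co1` gives 316000 nM, and compound 3 `COc1ccc(-c2nc(-c3c[nH]c4ccccc34)co2)cc1OC` gives 278000 nM; compound 2 sits among the other two with all three numbers inside the usual scatter, so none can be called the more or less active. Compound 4 `Oc1ccc(-c2nc(-c3c[nH]c4ccccc34)co2)cc1` is compound 2 with 4-hydroxyphenyl in place of methyl on an aromatic carbon. Within the data shown here, the only measured step bearing on this change is a 1.5-fold lower number from compound 1 to compound 2 (0.16 log units; within the scatter), which likewise exchanges a six-membered aromatic ring for a methyl and stays within the scatter. Because compound 1 and compound 3, each carrying such a ring, give numbers close to compound 2, only a step within the scatter is expected for compound 4, namely a 1.1-fold higher number from compound 2 to compound 4 (0.04 log units; within the scatter). Compound 4 is therefore estimated at 350000 nM in this assay, within a range from 150000 nM to 800000 nM.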

Compound 4, half-maximal inhibitory concentration: 449000 nM
Compound 4: middle estimate off by 1.3-fold (0.11 log units), on the low side; the range from low to high includes it.
By their numbers in this assay, from the lowest: compounds 3, 2, 4 and 1 (each within the scatter of the next).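

Replacing methyl with 4-hydroxyphenyl gives a 1.4-fold higher number from compound 2 to compound 4 (0.15 log units; within the scatter) and so shows that this carbon of the five-membered ring can carry a much larger group, one with a hydrogen-bond donor, without a change that can be read. Adding hydroxy to the phenyl ring gives a 1.0-fold lower number from compound 1 to compound 4 (0.01 log units; within the scatter) and shows that this small addition cannot be read either. Nothing available explains why these numbers stay so close. On these data alone, whether any group at this position can shift the number remains open, and a basic amine or a carboxylic acid on the phenyl ring would be one test of that.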